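A few compounds are considered here, and "the series" means these few. Any claim that something is new, unique, unknown or untested is made for them only; others in the source may bear on it.

Measured in a functional assay on A-375 cells (Homo sapiens) for antiproliferative activity, read by MTT assay, with a stated time of 24 h; on this read-out lower numbers stand for stronger inhibition and higher numbers for weaker inhibition:
compound 1 `C=CCOc1ccc2c(=O)c(-c3cc(OC)c(OC)cc3OC)coc2c1`: 4750 nM
compound 2 `COc1cc(OC)c(-c2coc3cc(OCc4cccc(Br)c4)ccc3c2=O)cc1OC`: 1120 nM
compound 3 `COc1cc(OC)c(-c2coc3cc(OCc4ccc(C(F)(F)F)cc4)ccc3c2=O)cc1OC`: 2280 nM

Compound 3 lies in the middle of the three numbers. Against the vinyl of the first entry, both aryl groups give lower numbers: a 4.2-fold lower number from compound 1 to compound 2 (0.63 log units; beyond the scatter) and a 2.1-fold lower number from compound 1 to compound 3 (0.32 log units; beyond the scatter). These steps are modest.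

Compound 4 `COc1cc(OC)c(-c2coc3cc(OCc4cccc(C(F)(F)F)c4)ccc3c2=O)cc1OC` keeps the shared core and has 3-(trifluoromethyl)phenyl in place of 4-(trifluoromethyl)phenyl on a saturated chain carbon bound to an oxygen on an aromatic ring.

Within the data shown here, no measured step isolates this change. The nearest guide is a 2.0-fold higher number from compound 2 to compound 3 (0.31 log units; beyond the scatter), which replaces 3-bromophenyl with 4-(trifluoromethyl)phenyl. That step changes the substituent as well, so it bears only weakly on the present change. The entering group's name matches the 3-bromophenyl of compound 2 in its number, so a small move towards lower numbers is expected. The estimated step is a 1.4-fold lower number from compound 3 to compound 4 (0.15 log units; within the scatter). Compound 4 is expected at 1600 nM, with an estimated range of 750 nM to 3400 nM.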

Compound 4, half-maximal inhibitory concentration: 1140 nM
Estimate against measurement, compound 4: 1.4-fold (0.15 log units) above; measured number inside the range.
By their numbers in this assay, from the lowest: compounds 2, 4 and 3 (each within the scatter of the next, the first and the last beyond it); then compound 1.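

In this assay, 3-(trifluoromethyl)phenyl in place of 4-(trifluoromethyl)phenyl on the saturated chain carbon gives a step that stays within the scatter (a 2.0-fold lower number from compound 3 to compound 4 (0.30 log units; within the scatter)), so this isomer pair is not resolved. Trifluoromethyl in place of bromo on the aromatic carbon is also unresolved (a 1.0-fold higher number from compound 2 to compound 4 (0.01 log units; within the scatter)), which separates the two changes combined in the step between compound 2 and compound 3. 3-(Trifluoromethyl)phenyl in place of vinyl gives a step beyond the scatter (a 4.2-fold lower number from compound 1 to compound 4 (0.62 log units; beyond the scatter)), and no supporting data offer an explanation for any of these steps.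

The compounds shown leave open how an unsubstituted benzyl would compare with these aryl groups. Also open, going by these compounds, is whether an amine or a carboxylic acid on that ring would keep the number near that of compound 4.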